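The source may report more compounds than this note shows. Statements on the series, on what has been measured and on what is new or still open speak of the compounds shown alone.

On a physicochemical assay for lipophilicity, read by HPLC, measured as chromatographic lipophilicity, at pH 7.4 (on this read-out higher numbers stand for higher lipophilicity and lower numbers for lower lipophilicity), compound 1 (`CC(=O)N1CCC(C(=O)N2N=CCC2c2ccccc2)CC1`) gives 2.5 and compound 2 (`CCC(=O)N1CCC(C(=O)N2N=CCC2c2ccccc2)CC1`) gives 3.2 while compound 3 (`O=C(C1CCCCC1)N1CCC(C(=O)N2N=CCC2c2ccccc2)CC1`) gives 5.4 and stands highest of the three. All three share one core and differ only in the group on a carbonyl carbon. Methyl in place of hydrogen on a saturated chain carbon bound to a carbonyl carbon comes with a number 0.70 log units higher from compound 1 to compound 2 (beyond the scatter) as a first and fairly small move. Cyclohexyl in place of methyl comes with a number 2.90 log units higher from compound 1 to compound 3 (beyond the scatter) and cyclohexyl in place of ethyl comes with a number 2.20 log units higher from compound 2 to compound 3 (beyond the scatter) so the cyclohexyl steps are much the larger.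

Compound 4 (`O=C(c1cc[nH]n1)N1CCC(C(=O)N2N=CCC2c2ccccc2)CC1`) has not yet been measured. Compared with compound 3 it carries 1H-pyrazol-3-yl in place of cyclohexyl on a carbonyl carbon. The two cyclohexyl steps are the closest guide here, since they show how far compound 3 sits from its smaller relatives. The entering ring is aromatic and contains nitrogen, so compound 4 is expected to return close to compound 1 at 2.5 and compound 2 at 3.2 rather than stay near compound 3. The expected change in this assay is large and downward, a number 2.40 log units lower from compound 3 to compound 4 (beyond the scatter) on this estimate. Compound 4 is estimated at 3 (range 2.4 to 3.6).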

Compound 4, distribution coefficient: 2.4
Compound 4: the middle estimate sits 0.60 log units above what was measured, within the range that was stated.
By their numbers in this assay, from the lowest: compounds 4 and 1 (each within the scatter of the next); then compound 2; then compound 3.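

In this assay, the place on the carbonyl carbon turns out to respond to more than the presence of a ring: 1H-pyrazol-3-yl in place of cyclohexyl gives a number 3.00 log units lower from compound 3 to compound 4 (beyond the scatter) even though both groups are single rings of similar heavy-atom count, one of carbon only and the other a five-membered aromatic ring with 2 hetero atoms. Set against the small chains, the same ring gives a number 0.80 log units lower from compound 2 to compound 4 (beyond the scatter) when it replaces ethyl and a number 0.10 log units lower from compound 1 to compound 4 (within the scatter) when it replaces methyl, so in this series a ring at this place can read level with a methyl group and need not raise the number at all. The data offered here include nothing that explains why this ring behaves so differently from cyclohexyl.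

The compounds shown leave open which feature of the entering ring goes with the drop, since aromatic character, the nitrogens and the hydrogen-bond donor all change together in this one step. A plain phenyl ring on the same carbonyl carbon, or a pyrazole carrying a methyl group on its ring nitrogen in place of that hydrogen, would begin to pull these features apart.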